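The compounds below may be only part of what the source reports. "The series", "measured", "known", "first", "only" and "open" are said of these compounds alone.

Compound 1 `Cn1cc(-c2ccc(C(F)(F)F)cc2)c2cc(F)c(C(=O)NS(=O)(=O)C3CC3)cc21` carries a cyclopropyl on its sulfonyl sulfur. In an ADME assay on a cell-free system (plasma, Homo sapiens) for protein binding (on this read-out lower numbers stand for a smaller free fraction and higher numbers for a larger free fraction), compound 1 gives 0.0025. Compound 2 `CC(C)COc1ncc(-c2cn(C)c3cc(C(=O)NS(=O)(=O)C4CC4)c(F)cc23)cc1Cl` is built on another core; the difference between the two cores is not broken down here. In this assay compound 2 gives < 0.001, which is a limit of the assay and not a number. Compound 3 `CC(C)COc1ncc(-c2cn(C)c3cc(C(=O)NS(C)(=O)=O)c(F)cc23)cc1Cl` differs from compound 2 by methyl in place of cyclopropyl on a sulfonyl sulfur. In this assay compound 3 gives 0.001. The step of a number no lower from compound 2 to compound 3 (the limit leaves the size open) cannot be given a size because of the limit of < 0.001 in this assay, at which 1 of the 3 values shown sits. Among the numbers shown, compound 1 stands highest, and the gap down to compound 3 lies beyond the usual scatter.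

Compound 4 `Cn1cc(-c2ccc(C(F)(F)F)cc2)c2cc(F)c(C(=O)NS(C)(=O)=O)cc21` has not yet been measured. It differs from compound 1 by methyl in place of cyclopropyl on a sulfonyl sulfur, the same change as that from compound 2 to compound 3, made at the same place. The earlier step left the unbound fraction no lower, with its size open. For compound 4 the step expected in this assay is a 1.2-fold higher number from compound 1 to compound 4 (0.08 log units; within the scatter). That expectation rests on compound 1 with its value of 0.0025 and on the direction of a number no lower from compound 2 to compound 3 (the limit leaves the size open). Compound 4 is therefore estimated to give 0.003, with a likely range from 0.0015 to 0.006.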

Compound 4, unbound fraction: 0.002
Beside the measured number, compound 4's estimate is 1.5-fold (0.18 log units) above it; low and high end bracket the measured number.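

Methyl in place of cyclopropyl on a sulfonyl sulfur gives a 1.3-fold lower number from compound 1 to compound 4 (0.10 log units; within the scatter) in this assay, so this step does not separate the two compounds. On the other core, compound 2 gives < 0.001, which is a limit of the assay and not a number. The step on that core cannot be read for size, so the figures do not show that the change carries from one core to the other with the same size, nor that it behaves differently on each: the same change on two cores in this assay, a number no lower (the limit leaves the size open) from compound 2 to compound 3 and a 1.3-fold lower number (0.10 log units; within the scatter) from compound 1 to compound 4; the limit leaves it open whether they differ

The compounds shown leave open what other groups on the sulfonyl sulfur, such as an ethyl, an isopropyl, a phenyl or a dimethylamino group, would do to the unbound fraction on either core. They also leave open whether any replacement at this place can move the unbound fraction on the core of compound 1 by more than the usual scatter.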